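The compounds below may be only part of what the source reports. "The series", "measured", "known", "first", "only" and "open" are said of these compounds alone.

In an ADME assay on HepG2 2.2.15 cells (Homo sapiens) for cytotoxicity, read by MTT assay (on this read-out lower numbers stand for higher toxicity in this test and higher numbers for lower toxicity in this test), compound 1 `C=C1CC[C@@H]2[C@](C)(COC(=O)/C=C/c3ccccc3)[C@H](O)CC[C@@]2(C)[C@@H]1C/C=C1\C=COC1=O` gives 271000 nM, compound 2 `C=C1CC[C@@H]2[C@](C)(CO)[C@H](OC(=O)/C=C/c3ccccc3)CC[C@@]2(C)[C@@H]1C/C=C1\C=COC1=O` gives 179000 nM and compound 3 `C=C1CC[C@@H]2[C@](C)(CO)[C@H](OC(=O)/C=C/c3cc(OC)c(OC)c(OC)c3)CC[C@@]2(C)[C@@H]1C/C=C1\C=COC1=O` gives 211000 nM. Compound 2 therefore stands within the scatter of both other compounds. Compound 4 `C=C1CC[C@@H]2[C@](C)(CO)[C@H](OC(=O)c3ccco3)CC[C@@]2(C)[C@@H]1C/C=C1\C=COC1=O` differs from compound 2 as follows: furan-2-yl in place of 2-phenylethenyl on a carbonyl carbon. In short, furan-2-yl sits in place of 2-phenylethenyl on a carbonyl carbon. Within the data shown here, only one measured step bears on this, and it is an indirect guide: a 1.2-fold higher number from compound 2 to compound 3 (0.07 log units; within the scatter), with 3,4,5-trimethoxyphenyl in place of phenyl. Among the measured compounds shown here, no measured step replaces the whole 2-phenylethenyl group. No step beyond the scatter is therefore expected in this assay. The expected change is a 1.1-fold higher number from compound 2 to compound 4 (0.05 log units; within the scatter). Compound 4 is estimated at 200000 nM, with an expected range of 105000 nM to 380000 nM.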

Compound 4, half-maximal cytotoxic concentration: 42000 nM
Estimate against measurement, compound 4: 4.8-fold (0.68 log units) above, outside the stated range (below it).
By their numbers in this assay, from the lowest: compound 4; then compounds 2, 3 and 1 (each within the scatter of the next).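

With furan-2-yl on this carbonyl carbon, this assay shows a 4.3-fold lower number from compound 2 to compound 4 (0.63 log units; beyond the scatter) and thus the only listed step beyond the scatter. Substitution on the phenyl ring of compounds 2 and 3 stayed within the scatter, so this position responds to exchange of the whole 2-phenylethenyl group. No measurement shown accounts for the step.

Still open, as far as these compounds go, is whether the loss of the double bond, the five-membered ring or its oxygen carries the step. Phenyl or thiophen-2-yl on this carbonyl carbon would separate these.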